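From Vinyl to Isopropyl on the Amide Carbonyl

The source may report more compounds than this note shows. Statements on the series, on what has been measured and on what is new or still open speak of the compounds shown alone.

Three amides sharing one core have been measured in a functional assay on MGC-803 cells (Homo sapiens) for inhibition, read by MTT assay, with a stated time of 48 h; a higher number here means a weaker inhibitor, a lower number a stronger inhibitor. Compound 1 `CCC(=O)N(Cc1ccc(OC)c(O)c1)c1cc(OC)c(OC)c(OC)c1` gives 50 nM. Compound 2 `C/C=C/C(=O)N(Cc1ccc(OC)c(O)c1)c1cc(OC)c(OC)c(OC)c1` gives 27 nM. Compound 3 `C=CC(=O)N(Cc1ccc(OC)c(O)c1)c1cc(OC)c(OC)c(OC)c1` gives 62 nM, the highest of the three numbers; its nearest neighbour is compound 1, and the step of a 1.2-fold higher number from compound 1 to compound 3 (0.09 log units; within the scatter) lies within the scatter, while the step of a 2.3-fold higher number from compound 2 to compound 3 (0.36 log units; beyond the scatter) is modest but beyond it.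

Compound 4 `COc1ccc(CN(C(=O)C(C)C)c2cc(OC)c(OC)c(OC)c2)cc1O` has not yet been measured. It differs from compound 3 by isopropyl in place of vinyl on a carbonyl carbon. Among the compounds with values here, two measured steps bear on this change. The step of a 1.2-fold higher number from compound 1 to compound 3 (0.09 log units; within the scatter) shows that trading a saturated ethyl for an unsaturated vinyl on the carbonyl carbon left the number essentially unchanged. The step of a 1.9-fold lower number from compound 1 to compound 2 (0.27 log units; within the scatter) shows that lengthening to prop-1-en-1-yl gave a gain that also stayed within the scatter. Within the data shown here, a branched, saturated isopropyl has no direct precedent among the measured compounds, so the expectation rests on the weak dependence seen so far: the step of a 1.2-fold lower number from compound 3 to compound 4 (0.09 log units; within the scatter) is expected to stay within the scatter. Compound 4 is therefore estimated at 50 nM, with a range from 25 nM to 110 nM.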

Compound 4, half-maximal inhibitory concentration: 210 nM
The estimate for compound 4 lay 4.2-fold (0.62 log units) below the measured number, outside the stated range (above it).
By their numbers in this assay, from the lowest: compounds 2, 1 and 3 (each within the scatter of the next, the first and the last beyond it); then compound 4.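

In this assay, within the data shown here, isopropyl is the first group on this carbonyl carbon to set a compound apart from all the others, making compound 4 the weakest of the four, with the step from the vinyl amide reading (a 3.4-fold higher number from compound 3 to compound 4 (0.53 log units; beyond the scatter)) and the step from the prop-1-en-1-yl amide, the largest in the set, reading (a 7.8-fold higher number from compound 2 to compound 4 (0.89 log units; beyond the scatter)). The closest comparison is with the ethyl amide, where methyl in place of hydrogen on the saturated chain carbon gives (a 4.2-fold higher number from compound 1 to compound 4 (0.62 log units; beyond the scatter)), so one added methyl at this carbon moves the number beyond the scatter, whereas the exchange of ethyl for vinyl did not (a 1.2-fold higher number from compound 1 to compound 3 (0.09 log units; within the scatter)). No measurement shown here explains this result.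

The compounds shown leave open whether the branching itself or simply the added carbon goes with the higher number, a question that an unbranched propyl chain on the same carbonyl carbon would help to settle. They also leave open how a cyclopropyl ring or a tert-butyl group would read at this position, and so how far the trend with substitution at this carbon extends.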